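The source may report more compounds than this note shows. Statements on the series, on what has been measured and on what is new or still open speak of the compounds shown alone.

In an ADME assay on MT4 cells (Homo sapiens) for cytotoxicity, read by MTT assay (a lower number here means that less compound is tolerated, a higher number that more compound is tolerated), compound 1 `Cc1ccc(N(C(=O)c2ccccc2C)C(=S)OCCN2C(=O)c3ccccc3C2=O)cc1` reads > 100000 nM, which is a limit of the assay and not a number. Compound 2 `Cc1ccc(N(C(=O)c2ccccc2[N+](=O)[O-])C(=S)OCCN2C(=O)c3ccccc3C2=O)cc1` gives 100000 nM and compound 3 `Cc1ccc(N(C(=O)c2cccc([N+](=O)[O-])c2)C(=S)OCCN2C(=O)c3ccccc3C2=O)cc1` gives 100000 nM, so compound 3 stands level with compound 2, with no change at the digits printed from compound 2 to compound 3 (within the scatter). Compound 4 `Cc1ccc(C(=O)N(C(=S)OCCN2C(=O)c3ccccc3C2=O)c2ccc(C)cc2)cc1` differs from compound 3 by 4-methylphenyl in place of 3-nitrophenyl on a carbonyl carbon, which puts 4-methylphenyl in place of 3-nitrophenyl on a carbonyl carbon. The closest measured swap runs the other way, with a number no higher from compound 1 to compound 3 (the limit leaves the size open), and a second nitro swap shows a number no higher from compound 1 to compound 2 (the limit leaves the size open), so neither step has a readable size. The expected result is no change at the digits printed from compound 3 to compound 4 (within the scatter), with no step beyond the scatter in this assay. For compound 4 the estimated value is 100000 nM, within an expected range of 50000 nM to 200000 nM.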

Compound 4, half-maximal cytotoxic concentration: 83000 nM
Compound 4: middle estimate off by 1.2-fold (0.08 log units), on the high side, and the stated range covers the measured number.
By their numbers in this assay, from the lowest: compounds 4, 2 and 3 (each within the scatter of the next).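

In this assay, 4-methylphenyl in place of a nitro-bearing ring on this carbonyl carbon gives a 1.2-fold lower number from compound 3 to compound 4 (0.08 log units; within the scatter), and likewise a 1.2-fold lower number from compound 2 to compound 4 (0.08 log units; within the scatter). This position therefore now holds a ring without nitro as well as the two rings with it, and no readable step here lies beyond the scatter. Against 2-methylphenyl, the change gives an at least 1.2-fold lower number from compound 1 to compound 4 (0.08 log units; that floor lies within the scatter), and its full size cannot be read: the limit of > 100000 nM in this assay, at which 1 of the 4 values shown sits.

All four compounds carry a substituted phenyl ring at this position. As far as these compounds go, what an amine, a carboxylic acid or a longer chain would do there stays open.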